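This account rests on a few compounds, and the source may have more. Where it says the series, first, only, none or still open, it means among the compounds named here.

Working notes on the series. In an assay on CHO cells for displacement of a labelled ligand from melanin-concentrating hormone receptor 1 (Homo sapiens), read by scintillation counting, with a stated time of 1 h (a lower number here means a stronger inhibitor, a higher number a weaker inhibitor), compound 1 `Cc1c(C2CC2)nc2ccc(-n3ccc(OCc4ccccc4)cc3=O)cn12` gives 42 nM. Among the measured compounds shown here, compound 2 `Cc1c(C2CC2)nc2ccc(-n3ccc(OCc4ccccn4)cc3=O)cn12` carries a pyridin-2-yl group where compound 1 has phenyl, and in this assay compound 2 gives 240 nM; that is the higher of the two numbers measured so far, the step being a 5.7-fold higher number from compound 1 to compound 2 (0.76 log units; beyond the scatter).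

The next compound, compound 3 `Cc1c(C2CC2)nc2ccc(-n3ccc(OCc4cccnc4)cc3=O)cn12`, differs from compound 2 by pyridin-3-yl in place of pyridin-2-yl on a saturated chain carbon bound to an oxygen on an aromatic ring. For the measured compounds named here, no measured step moves the ring nitrogen from one position to another; the only step available, a 5.7-fold higher number from compound 1 to compound 2 (0.76 log units; beyond the scatter), concerns adding the nitrogen, not relocating it, so it gives no direction for this change. With nothing to anchor a shift, no step beyond the scatter is expected in this assay, though the range must stay wide.

Compound 3 is therefore expected to sit near compound 2, with the step estimated as a 1.2-fold lower number from compound 2 to compound 3 (0.08 log units; within the scatter). For compound 3 the estimate in this assay is 200 nM, expected to fall between 60 nM and 650 nM.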

Compound 3, half-maximal inhibitory concentration: > 1000 nM
Compound 3: only a limit was reported; the forecaster's own chance of this, stated with the estimate: 3%; middle value at least 5.0-fold (0.69 log units) from the limit.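

Compound 3 is reported only as a limit: the limit of > 1000 nM in this assay, at which 1 of the 3 values shown sits.

Moving the ring nitrogen while the atoms stay the same gives an at least 4.1-fold higher number from compound 2 to compound 3 (0.61 log units; beyond the scatter), so on a saturated chain carbon bound to an oxygen on an aromatic ring the place of the nitrogen matters, not only its presence. Against phenyl, pyridin-3-yl gives an at least 23-fold higher number from compound 1 to compound 3 (1.37 log units; beyond the scatter), which leaves phenyl with the lowest number of the three groups shown.

Where the true value of compound 3 lies remains open, and the compounds shown do not settle why the nitrogen's place matters. Also open, from the compounds shown here alone, is how pyridin-4-yl, a fluorophenyl group or a longer chain on the oxygen would compare at this place.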